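Ring substitution on the shared core: projecting compound 3

This account rests on a few compounds, and the source may have more. Where it says the series, first, only, none or still open, it means among the compounds named here.

Measured so far in an assay on isolated protein for inhibition of AP2-associated protein kinase 1 (Homo sapiens), with a stated time of 3 h, in the presence of a further agent that is not named here; a higher number here means a weaker inhibitor, a lower number a stronger inhibitor:
- compound 1, `COC(=O)Nc1cc(-c2ccc(OC[C@@](C)(N)CC(C)C)nc2)ccn1`, gives 28 nM
- compound 2, `COC(=O)Nc1cc(-c2cc(C)c(OC[C@@](C)(N)CC(C)C)cn2)ccn1`, gives 1.7 nM

Compound 1 stands at the higher of the two numbers; the value of compound 2 is lower, and the gap between them lies beyond the scatter. Among the compounds with values here, no step between the two measured compounds is computed, so their two values are all that is known of that pair.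

Compound 3, `COC(=O)Nc1cc(-c2cnc(OC[C@@](C)(N)CC(C)C)c(OC)c2)ccn1`, is not yet measured. It differs from compound 1 by methoxy in place of hydrogen on an aromatic carbon. Within the data shown here, no measured pair isolates this change, so its effect cannot be read from the numbers. Compound 2 also carries an added group and gives the lower number, but that is a different change and supports no more than a guess at direction. A moderate lowering of the number is expected, with wide uncertainty. In this assay the expected step is a 2.8-fold lower number from compound 1 to compound 3 (0.45 log units; beyond the scatter). For compound 3 the expected value in this assay is 10 nM, within 3 nM to 40 nM.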

Compound 3, half-maximal inhibitory concentration: 3.8 nM
Compound 3: the middle estimate sits 2.6-fold (0.42 log units) above what was measured, and the stated range covers the measured number.
By their numbers in this assay, from the lowest: compound 2; then compound 3; then compound 1.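

In this assay, within the data shown here, methoxy in place of hydrogen on an aromatic carbon, ortho to the (2-amino-2,4-dimethylpentyl)oxy group, gives a 7.4-fold lower number from compound 1 to compound 3 (0.87 log units; beyond the scatter), the first change in a single place with a measured size. The step shows that this position of the shared core tolerates methoxy without loss and that the number falls beyond the scatter, though a single pair speaks only for this group at this position. No measurement at hand bears on what lies behind the step.

As far as these compounds go, it remains open whether the oxygen matters or whether any small group would give a similar step, a question that methyl, ethoxy or a fluorine atom at the same position would address. A longer alkoxy chain there would show how much larger the group can become before the number rises again.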